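Halogen Swap on Two Nitroaryl Tetrazole Cores

A few compounds are considered here, and "the series" means these few. Any claim that something is new, unique, unknown or untested is made for them only; others in the source may bear on it.

Compound 1 `O=[N+]([O-])c1cc(-c2nnn(Cc3ccc(Cl)cc3)n2)cc([N+](=O)[O-])c1` carries a chloro group on its outer ring. In an ADME assay on CHO-K1 cells (Cricetulus griseus) for cytotoxicity, read by MTT assay, with a stated time of 24 h (a higher number here means a weaker inhibitor, a lower number a stronger inhibitor), compound 1 gives 170000 nM. Compound 2 `O=[N+]([O-])c1cc(-c2nnn(Cc3ccc(Br)cc3)n2)cc([N+](=O)[O-])c1` differs from it in one place, (bromo in place of chloro on an aromatic carbon), and in this assay compound 2 gives 55000 nM. That single change made a 3.1-fold lower number from compound 1 to compound 2 (0.49 log units; beyond the scatter). Compound 3 `O=[N+]([O-])c1cc(-c2nnn(CSc3nnnn3-c3ccc(Cl)cc3)n2)cc([N+](=O)[O-])c1` is built on a different core; how the two cores differ is not broken down here. In this assay compound 3 gives 14000 nM, the lowest of the three numbers, standing beyond the scatter from both compound 2 and compound 1.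

Compound 4 `O=[N+]([O-])c1cc(-c2nnn(CSc3nnnn3-c3ccc(Br)cc3)n2)cc([N+](=O)[O-])c1` has not yet been measured. It differs from compound 3 in one place, (bromo in place of chloro on an aromatic carbon), the same kind of change as that from compound 1 to compound 2, again on an aromatic carbon of a six-membered aromatic ring of carbon only, para to a large group. What differs around the place is that in the first pair the change can also be read as 4-chlorobenzyl to 4-bromobenzyl, a reading the second pair does not share. On that one earlier instance, the step in this assay is expected to be a 2.8-fold lower number from compound 3 to compound 4 (0.45 log units; beyond the scatter), resting on compound 1 and compound 2 because a 3.1-fold lower number from compound 1 to compound 2 (0.49 log units; beyond the scatter). A single prior example is thin support, so the range is kept wide. Compound 4 is estimated to give 5000 nM in this assay, between 2000 nM and 12000 nM.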

Compound 4, half-maximal inhibitory concentration: 29000 nM
The estimate for compound 4 lay 5.8-fold (0.76 log units) below the measured number, and the stated range ends below it.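

On the core of compound 3, bromo in place of chloro on the aromatic carbon gave a 2.1-fold higher number from compound 3 to compound 4 (0.32 log units; beyond the scatter) in this assay and so ran the opposite way to the step on the core of compound 1. Set side by side, the two instances disagree in direction, and the gap between them is larger than repeat measurements would explain: the same change on two cores in this assay, a 3.1-fold lower number (0.49 log units; beyond the scatter) from compound 1 to compound 2 and a 2.1-fold higher number (0.32 log units; beyond the scatter) from compound 3 to compound 4, 6.4-fold (0.81 log units) apart, beyond the scatter of two such steps. This shows that, among these four compounds, the effect of the swap did not carry from one core to the other, so a step seen on one core could not be relied on for the other; it does not show which feature of the cores sets the two steps apart, and two pairs give no rule for any further core.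

The compounds shown carry only chloro or bromo at this place on the ring, so it remains open how fluoro, methyl or methoxy there would behave on either core, and whether such groups would also give opposite steps on the two cores. From the compounds shown here alone, it also remains open whether the opposite steps would recur in a different cell line or over a different exposure time.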